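The source may report more compounds than this note shows. Statements on the series, on what has been measured and on what is new or still open speak of the compounds shown alone.

In a functional assay on P388 cells (Mus musculus) for antiproliferative activity, read by colorimetric assay and MTT assay (on this read-out lower numbers stand for stronger inhibition and higher numbers for weaker inhibition), compound 3 `O=[N+]([O-])c1ccc(S(=O)(=O)Nc2cccc3c(Cl)c[nH]c23)cc1` gives 2.3 ug/mL. Compound 2 `O=[N+]([O-])c1ccc(S(=O)(=O)Nc2cccc3cc[nH]c23)cc1` gives 8.2 ug/mL, and placing chloro in place of hydrogen on an aromatic carbon accounts for a 3.6-fold lower number from compound 2 to compound 3 (0.55 log units; beyond the scatter). Compound 1 `O=S(=O)(Nc1cccc2c(Cl)c[nH]c12)c1ccc(Cl)cc1` gives 4.3 ug/mL, a value that cannot be told apart from that of compound 3. Compound 3 therefore shares the low end of this small set with compound 1 and stands clearly below compound 2.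

The next molecule, compound 4 `N#Cc1ccc(S(=O)(=O)Nc2cccc3c(Cl)c[nH]c23)cc1`, keeps the shared core and carries cyano in place of nitro on an aromatic carbon. The chloro step lies in a different part of the molecule, so it offers little guidance here. The closer precedent is nitro in place of chloro at the same aromatic carbon, which gave only a 1.9-fold lower number from compound 1 to compound 3 (0.27 log units; within the scatter). With just that one exchange to go on, no step beyond the scatter is expected in this assay.

The expected step is a 1.4-fold higher number from compound 3 to compound 4 (0.14 log units; within the scatter). For compound 4, the estimated value is 3.2 ug/mL, with an expected range from 1.3 ug/mL to 7.5 ug/mL.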

Compound 4, half-maximal inhibitory concentration: 1.4 ug/mL
Compound 4: the middle estimate sits 2.3-fold (0.36 log units) above what was measured; low and high end bracket the measured number.
By their numbers in this assay, from the lowest: compounds 4, 3, 1 and 2 (each within the scatter of the next, the first and the last beyond it).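

Moving from nitro to cyano on this aromatic carbon, para to a large group, gives a 1.6-fold lower number from compound 3 to compound 4 (0.22 log units; within the scatter), so the lost heavy atom brings no change that can be told from assay noise. The position shows a clearer difference when chloro is the starting point: a 3.1-fold lower number from compound 1 to compound 4 (0.49 log units; beyond the scatter), whereas compound 3 lies within the scatter of both compound 1 and compound 4. Nothing measured here explains why these groups differ.

Still open, on these data alone, is whether an amine, a carboxylic acid or a longer chain on this carbon would keep the number this low. Also open is how cyano behaves with hydrogen in place of chloro on the shared core, a form shown only for nitro in compound 2.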